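The source may report more compounds than this note shows. Statements on the series, on what has been measured and on what is new or still open speak of the compounds shown alone.

Measured compounds in a functional assay on A549 cells (Homo sapiens) for antiproliferative activity, read by MTT assay, with a stated time of 72 h; a lower number here means a stronger inhibitor, a higher number a weaker inhibitor:

compound 1, `CCNC(=O)c1cc(Oc2ccc(NC(=O)c3nn(-c4ccc(Br)cc4F)c(=O)cc3C)cc2)ccn1`: 34500 nM
compound 2, `CCNC(=O)c1cc(Oc2ccc(NC(=O)c3nn(-c4ccccc4C)c(=O)cc3C)cc2)ccn1`: 34800 nM
compound 3, `CCCNC(=O)c1cc(Oc2ccc(NC(=O)c3nn(-c4ccc(Br)cc4F)c(=O)cc3C)cc2F)ccn1`: 235000 nM

Compounds 1 and 2 share one core, and compound 3 carries another; the difference between the two cores is not broken down here. Within the first pair, the only change is 2-methylphenyl in place of 4-bromo-2-fluorophenyl on an aromatic nitrogen, and in this assay it made a step of a 1.0-fold higher number from compound 1 to compound 2 (0.00 log units; within the scatter), so the two compounds sit within the scatter of each other and no order can be read between them. Compound 3 stands apart from both: its number is higher than that of compound 2 and of compound 1 by gaps that lie beyond the scatter, so on its own core it is the weakest inhibitor of the three.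

Compound 4, `CCCNC(=O)c1cc(Oc2ccc(NC(=O)c3nn(-c4ccccc4C)c(=O)cc3C)cc2F)ccn1`, has not yet been measured. Within the data shown here, it arises from compound 3 by 2-methylphenyl in place of 4-bromo-2-fluorophenyl on an aromatic nitrogen, the same change as the one from compound 1 to compound 2. Since that change left the number essentially unmoved, as the step of a 1.0-fold higher number from compound 1 to compound 2 (0.00 log units; within the scatter) shows, the expectation for compound 4 is a step of about no change at the digits printed from compound 3 to compound 4 (within the scatter) on this assay, resting on that single earlier example. Compound 4 is therefore estimated at 235000 nM in this assay, with a range from 100000 nM to 550000 nM.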

Compound 4, half-maximal inhibitory concentration: 25700 nM
The estimate for compound 4 lay 9.1-fold (0.96 log units) above the measured number; measured number outside the range, below it.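

In this assay, putting 2-methylphenyl in place of 4-bromo-2-fluorophenyl on the aromatic nitrogen gave a 9.1-fold lower number from compound 3 to compound 4 (0.96 log units; beyond the scatter), whereas the same change had left the number essentially unmoved on the other core. The change therefore does not carry a fixed effect from one core to the other in this series, and its size depends on the core that bears it: the same change on two cores in this assay, a 1.0-fold higher number (0.00 log units; within the scatter) from compound 1 to compound 2 and a 9.1-fold lower number (0.96 log units; beyond the scatter) from compound 3 to compound 4, 9.2-fold (0.96 log units) apart, beyond the scatter of two such steps

What this does not show is which part of the difference between the two cores goes with the different outcome, or why the step is large on one core and absent on the other. With a single pair on each core, it also gives no rule for how the change would behave on any further core.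

The compounds shown leave open whether a plain phenyl or a 4-bromophenyl on the aromatic nitrogen would follow the same course on the two cores. They also leave open how a longer chain, such as butyl, on the amide nitrogen would alter the step.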